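Trifluoromethyl in Place of Nitro: Expectation for Compound 4

The source may report more compounds than this note shows. Statements on the series, on what has been measured and on what is new or still open speak of the compounds shown alone.

Three compounds share one core. Compound 1 is `CCOC(=O)c1c(N)sc(-c2ccccc2)c1-c1cccc(C(F)(F)F)c1`, compound 2 is `CCOC(=O)c1c(N)sc(-c2cccc(C(C)=O)c2)c1-c1cccc(C(F)(F)F)c1` and compound 3 is `CCOC(=O)c1c(N)sc(-c2ccc([N+](=O)[O-])cc2)c1-c1cccc(C(F)(F)F)c1`. In a functional assay on CHO-K1 cells for agonist activity at adenosine receptor A1 (Homo sapiens), read by GTPgammaS binding (a lower number here means that less compound is needed, a higher number that more compound is needed for the effect), compound 1 gives only a limit, > 10 uM. Compound 2 likewise reaches only a limit in this assay, > 10 uM. Compound 3 too shows a limit in this assay, > 10 uM. Compound 3 thus stands at the limit, where the two other compounds also stand. The steps among the three remain unreadable: a step that the two limits leave unreadable from compound 1 to compound 2, a step that the two limits leave unreadable from compound 1 to compound 3 and a step that the two limits leave unreadable from compound 2 to compound 3. The common ground of all three values is the limit of > 10 uM in this assay, at which 3 of the 3 values shown sit.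

Compound 4 is `CCOC(=O)c1c(N)sc(-c2ccc(C(F)(F)F)cc2)c1-c1cccc(C(F)(F)F)c1`. It differs from compound 3 by trifluoromethyl in place of nitro on an aromatic carbon. Each of the measured steps runs from one limit to another, so none of them has a readable size or direction. Going by the values given here, no direction can therefore be read for the step expected in this assay; the measured compounds suggest only that compound 4 is also expected to sit at or beyond the limit, with a number below it remaining possible. Compound 4 is estimated at 15 uM, with a range from 4 uM to 60 uM. The expected step is a step that the limit leaves unreadable from compound 3 to compound 4.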

Compound 4, concentration for half-maximal effect: > 10 uM
Compound 4 ended at the assay's limit; the forecaster's own chance of this, stated with the estimate: 80%; the middle value does not contradict the limit.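

None of the steps from compound 1, compound 2 or compound 3 to compound 4 can be read, and all four compounds stand at one place: the limit of > 10 uM in this assay, at which 4 of the 4 values shown sit. The compounds shown leave open whether any change on the shared core would give a measurable number in this assay, and how the four compounds truly compare.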